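A few compounds are considered here, and "the series" means these few. Any claim that something is new, unique, unknown or untested is made for them only; others in the source may bear on it.

Of the compounds shown here, two built on one shared core have been tested in a functional assay on CHO cells for agonist activity at adenosine receptor A1 (Homo sapiens), read by fluorescence and ERK phosphorylation, with stated times of 30 min and 1.5 h, tested at 10 uM; a higher number here means a stronger effect of the compound at the concentration tested, a lower number a weaker effect. Compound 1 `Nc1scc(-c2cccc(Cl)c2)c1C(=O)c1ccccc1` gives 52%. Compound 2 `Nc1scc(-c2ccccc2F)c1C(=O)c1ccc(Cl)cc1` gives 87%, the higher of the two numbers, and its gap to compound 1 lies beyond the usual scatter. Compound 3 `Nc1scc(-c2cccc(Cl)c2)c1C(=O)c1ccc(Cl)cc1` has not yet been measured. It differs from compound 2 in one place: 3-chlorophenyl in place of 2-fluorophenyl on an aromatic carbon. The 3-chlorophenyl group is also found in compound 1, whose weaker result suggests a downward step. The step from compound 2 to compound 3 is expected to be a number 17 percentage points lower from compound 2 to compound 3 (beyond the scatter). Compound 3 is estimated to give 70%, most likely between 48% and 92%.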

Compound 3, a percentage reported as activity, at one concentration (the size of the read-out at that concentration, not a potency): 75%
The estimate for compound 3 lay 5 percentage points below the measured number, within the range that was stated.
By their numbers in this assay, from the lowest: compound 1; then compound 3; then compound 2.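

Replacing 2-fluorophenyl with 3-chlorophenyl on this aromatic carbon gives a number 12 percentage points lower from compound 2 to compound 3 (beyond the scatter) and so lowers the effect even with the chloro group on the other ring kept in place. Chloro in place of hydrogen on an aromatic carbon gives a number 23 percentage points higher from compound 1 to compound 3 (beyond the scatter) when 3-chlorophenyl is kept, so this chloro raises the effect in that setting. Still open, on these data alone, is whether the same chloro would raise the effect with 2-fluorophenyl present, and how a methoxy group or an amine would fare on either aromatic carbon. Nothing measured here explains either step.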